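Nitro substitution on two dihydropyrimidine-type cores at the calcium channel

This account rests on a few compounds, and the source may have more. Where it says the series, first, only, none or still open, it means among the compounds named here.

Measured compounds:
Compound 1, `COC(=O)C1=C(C)N=C(SC)NC1c1ccccc1SC`: 1520 nM
Compound 2, `COC(=O)C1=C(C)N=C(SC)NC1c1cc([N+](=O)[O-])ccc1SC`: 2700 nM
Compound 3, `CSC1=NC(c2ccccc2SC)C2=C(O)OCC2=N1`: 45200 nM

In an assay on Myocardium (Cavia porcellus) for displacement of a labelled ligand from Voltage-dependent L-type calcium channel subunit alpha-1C (Homo sapiens) (a lower number here means tighter binding, a higher number weaker binding), compound 1 gives 1520 nM and compound 2 gives 2700 nM. The two differ by nitro in place of hydrogen on an aromatic carbon, and the step is a 1.8-fold higher number from compound 1 to compound 2 (0.25 log units; within the scatter). Compound 3 carries a different core; the difference between the two cores is not broken down here. Compound 3, in this assay, gives 45200 nM, which stands beyond the scatter from both compound 1 and compound 2.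

Compound 4, `CSC1=NC(c2cccc([N+](=O)[O-])c2SC)C2=C(O)OCC2=N1`, has not been measured. It differs from compound 3 by nitro in place of hydrogen on an aromatic carbon. This is the same kind of change as that from compound 1 to compound 2, though the place differs: in compound 4 the nitro sits ortho to a methylsulfanyl group, whereas in compound 2 it sits para to a methylsulfanyl group. Resting on the step of a 1.8-fold higher number from compound 1 to compound 2 (0.25 log units; within the scatter), the expected step for compound 4 in this assay is a 1.5-fold higher number from compound 3 to compound 4 (0.19 log units; within the scatter). Compound 4 is therefore estimated at 70000 nM, with a range from 30000 nM to 200000 nM.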

Compound 4, dissociation constant: 13700 nM
For compound 4 the middle estimate is 5.1-fold (0.71 log units) above the measured one; measured number below the stated range.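

On the core of compound 3, nitro in place of hydrogen on an aromatic carbon gave a 3.3-fold lower number from compound 3 to compound 4 (0.52 log units; beyond the scatter) in this assay, a modest gain in binding. Set beside the step on the core of compound 1, this shows that the change cannot be carried from one core to the other as a fixed shift in this series: the same change on two cores in this assay, a 1.8-fold higher number (0.25 log units; within the scatter) from compound 1 to compound 2 and a 3.3-fold lower number (0.52 log units; beyond the scatter) from compound 3 to compound 4, 5.9-fold (0.77 log units) apart, beyond the scatter of two such steps It does not show that the core alone accounts for the gap, as the nitro in compound 4 is ortho to a methylsulfanyl group and stands at a different place in compound 2, so the two steps differ in both core and place and cannot be separated here.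

The compounds shown leave open whether nitro at one and the same place on both cores would give steps that agree. They also leave open whether an amine or a carboxylic acid on the same aromatic carbon would move the number in the same direction on both cores.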